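A few compounds are considered here, and "the series" means these few. Any claim that something is new, unique, unknown or untested is made for them only; others in the source may bear on it.

Going by the values given here, compound 1, with the structure `COc1ccc(NC(=O)Nc2nc(Sc3c[nH]c4ccccc34)cc(N3CCCCC3)n2)cc1`, is the only compound here that gives an actual number: in a functional assay on MDA-MB-231 cells (Homo sapiens) for inhibition, with a stated time of 72 h (on this read-out lower numbers stand for stronger inhibition and higher numbers for weaker inhibition), compound 1 gives 7260 nM. Compound 2, with the structure `COc1cc(NC(=O)Nc2nc(Nc3cc(OC)cc(OC)c3)cc(Sc3c[nH]c4ccccc34)n2)cc(OC)c1`, carries a different picture: in this assay compound 2 gives only > 50000 nM, which is a limit of the assay and not a number. That value sits at the limit of > 50000 nM in this assay, at which 1 of the 2 values shown sits. Among the compounds with values here, no step between two measured compounds is on hand, so nothing yet shows how a single change moves the number.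

Compound 3, with the structure `O=C(Nc1ccccc1)Nc1nc(Sc2c[nH]c3ccccc23)cc(N2CCCCC2)n1`, differs from compound 1 by hydrogen in place of methoxy on an aromatic carbon, a change on an aromatic carbon of a six-membered aromatic ring of carbon only, para to a large group. Within the data shown here, from the one number available, the step of a 1.2-fold higher number from compound 1 to compound 3 (0.09 log units; within the scatter) is expected to stay within the usual scatter, or at most to weaken inhibition slightly. Compound 3 is therefore estimated at 9000 nM, within a range of 3500 nM to 25000 nM.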

Compound 3, half-maximal inhibitory concentration: 8130 nM
For compound 3 the middle estimate is 1.1-fold (0.04 log units) above the measured one; low and high end bracket the measured number.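

Going from 4-methoxyphenyl to phenyl gives a 1.1-fold higher number from compound 1 to compound 3 (0.05 log units; within the scatter) in this assay and is the first single change in this series that can be read. At this place, on the aromatic carbon para to a large group, the methoxy can be replaced by hydrogen with no difference that can be told apart from the usual scatter. For this pair, then, the methoxy is not needed to keep the inhibition seen with compound 1. Nothing on hand bears on why these two numbers agree.

The compounds shown leave open whether an amine, a carboxylic acid or a longer chain such as butoxy at this same place would move the number. They also leave open how single changes elsewhere on the core of compound 1 would act.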